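Z to E at the double bond of compound 3

The compounds below may be only part of what the source reports. "The series", "measured", "known", "first", "only" and "open" are said of these compounds alone.

Within the data shown here, the series is read in a functional assay on HeLa cells (Homo sapiens) for antiproliferative activity, read by sulforhodamine B assay, with a stated time of 72 h (a higher number here means a weaker inhibitor, a lower number a stronger inhibitor), and three compounds have values so far. Compound 1 `Fc1ccc(/C=C/c2cc3ccccc3nc2Cl)cc1` gives > 50000 nM as a limit of the assay and not a number. Compound 2 `COc1ccc2nc(Cl)c(/C=C/c3ccc(C(F)(F)F)cc3)cc2c1` gives > 50000 nM as a limit of the same kind. Compound 3 `COc1ccc2nc(Cl)c(/C=C\c3ccc(F)cc3)cc2c1` gives 9670 nM as the only true number shown. The picture so far is the limit of > 50000 nM in this assay, at which 2 of the 3 values shown sit, and compound 3 alone clear of it.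

Compound 4 `COc1ccc2nc(Cl)c(/C=C/c3ccc(F)cc3)cc2c1` is the next to be read. Against compound 3 it shows (the two compounds have the same atoms and bonds and differ only in configuration as drawn: 1 of 1 stereo elements differ; a double bond is drawn Z in compound 3 and E in compound 4), with the double bond drawn Z in compound 3 and E in compound 4. Among the measured compounds shown here, no measured pair in the set isolates this change, so its size in this assay has to be judged indirectly. The double bond is also drawn E in compound 1 and in compound 2, and neither gives a number, though both differ from compound 4 elsewhere as well. A move toward weaker inhibition is therefore expected, beyond the scatter, and a reading that reports only the limit is quite possible. The estimated step is a 4.1-fold higher number from compound 3 to compound 4 (0.62 log units; beyond the scatter) in that direction. For compound 4 the expected value is 40000 nM, with an estimated range from 15000 nM to 50000 nM.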

Compound 4, half-maximal inhibitory concentration: > 50000 nM
Compound 4: no number, only a limit; the forecaster's own chance of this, stated with the estimate: 60%; at least 1.2-fold (0.09 log units) between middle value and limit.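

In this assay, the double bond is the only place that changes in this pair, and inverting it from Z to E gives an at least 5.1-fold higher number from compound 3 to compound 4 (0.71 log units; beyond the scatter), so the difference can be laid to configuration alone: the fact that compounds 3 and 4 differ only in the configuration as drawn

Compound 4 gives > 50000 nM, which is a limit of the assay and not a number, so the step has a floor but no known size. The steps to compound 4 from compound 1 and from compound 2 cannot be read, and among the compounds shown only the Z compound gives a number, while all three E compounds stay at the same limit: the limit of > 50000 nM in this assay, at which 3 of the 4 values shown sit.

Compound 3 is the only Z compound shown, so it remains open whether a Z double bond keeps a measurable value without the methoxy or with trifluoromethyl in place of the fluoro. Also open, from the compounds shown here alone, is how a Z compound carrying an amine or a carboxylic acid in place of the fluoro would read in this assay.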